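Urea in Place of Amide on a Pyrazole Scaffold

The source may hold more compounds than are shown below. What is called first, only, known or untested is meant among the compounds shown, and "the series" means these compounds.

Measured compounds:
compound 1 `O=C(Nc1cccc(-n2cc(-c3ccncc3)c(-c3ccc(Cl)c(O)c3)n2)c1)Nc1cccc(C(F)(F)F)c1` — > 32500 nM
compound 2 `COc1cc(-c2nn(-c3cccc(NC(=O)Nc4cc(C(F)(F)F)cc(C(F)(F)F)c4)c3)cc2-c2ccncc2)ccc1Cl` — 29600 nM
compound 3 `COc1cc(-c2nn(-c3cccc(NC(=O)c4cccc(C(F)(F)F)c4)c3)cc2-c2ccncc2)ccc1Cl` — > 50000 nM

Of the compounds shown here, three have been tested in a functional assay on BT-549 cells (Homo sapiens) for inhibition, read by sulforhodamine B assay, with a stated time of 48 h; on this read-out lower numbers stand for higher toxicity in this test and higher numbers for lower toxicity in this test. For compound 1 the result is a limit of the assay, > 32500 nM, and not a number. Compound 2 gives a measured number, 29600 nM. For compound 3 the result is again only a limit, > 50000 nM; it is the higher of the two limits shown, as the line the limit of > 50000 nM in this assay, at which 1 of the 3 values shown sits, marks, while the other limit stands at the limit of > 32500 nM in this assay, at which 1 of the 3 values shown sits. Compound 3 therefore sits at the less toxic edge of what this set shows, with no number of its own.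

Compound 4 `COc1cc(-c2nn(-c3cccc(NC(=O)Nc4ccc(Cl)c(Cl)c4)c3)cc2-c2ccncc2)ccc1Cl` is not yet measured. It differs from compound 3 in one place: (3,4-dichlorophenyl)amino in place of 3-(trifluoromethyl)phenyl on a carbonyl carbon. Cut one bond further out, the same change reads (3-(trifluoromethyl)phenyl)carbonyl to (3,4-dichlorophenyl)carbamoyl, which makes compound 4 a urea like compound 1 and compound 2. Since those two ureas gave a limit and a weak number, compound 4 is expected to stay weak as well, with a step of an at least 1.4-fold lower number from compound 3 to compound 4 (0.15 log units; that floor lies within the scatter) that cannot be fixed against a bare limit. The estimate for compound 4 is 35000 nM, with a range from 15000 nM to 60000 nM.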

Compound 4, concentration lethal to 50% of the cells: > 50000 nM
Compound 4: only a limit was reported; the forecaster's own chance of this, stated with the estimate: 45%; middle value at least 1.4-fold (0.15 log units) away from the limit.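

In this assay compound 4 gives only a limit of the assay, > 50000 nM. Compound 3 also has only a limit there, so no step can be read between compound 3 and compound 4. The compounds shown leave open whether the urea of compound 4 differs at all from the amide of compound 3 in this test.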